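Series notes: acetyl in place of 2-(2-hydroxyethoxy)ethyl

The compounds below may be only part of what the source reports. "The series", "measured", "known", "first", "only" and "open" are said of these compounds alone.

Compound 1 `Nc1nn(CCOCCO)c2nnc(-c3ccccc3)c(-c3ccccc3)c12` carries a 2-(2-hydroxyethoxy)ethyl on an aromatic nitrogen of the shared core. In a functional assay on HeLa cells (Homo sapiens) for cytotoxicity (on this read-out higher numbers stand for weaker inhibition and lower numbers for stronger inhibition), compound 1 returns only a limit of the assay, > 100000 nM, and no single number. Compound 2 `CC(=O)Nc1[nH]nc2nnc(-c3ccccc3)c(-c3ccccc3)c12` in this assay likewise reaches only a limit, > 100000 nM. Compound 3 `NNc1[nH]nc2nnc(-c3ccccc3)c(-c3ccccc3)c12` has no result in this assay, "not determined" (no result reported). Among the values shown, compound 1 therefore stands at the limit together with compound 2, and nowhere in the set is a single figure given; this is expressed by the limit of > 100000 nM in this assay, at which 2 of the 3 values shown sit, and because of the limit of > 100000 nM in this assay, at which 2 of the 3 values shown sit, no measured step between any two compounds can be stated.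

Compound 4 `CC(=O)n1nc(N)c2c(-c3ccccc3)c(-c3ccccc3)nnc21` differs from compound 1 by acetyl in place of 2-(2-hydroxyethoxy)ethyl on an aromatic nitrogen. Within the data shown here, with no measured step in the set, the size of the move from compound 1 to compound 4 cannot be read from measured pairs. The expectation is that the step that the limit leaves unreadable from compound 1 to compound 4 amounts to nothing beyond the scatter, since compound 1 itself gives only the limit > 100000 nM. For compound 4 in this assay the estimate is 150000 nM, within an expected range from 50000 nM to 500000 nM, most likely again reported as a limit.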

Compound 4, half-maximal inhibitory concentration: > 100000 nM
Compound 4 was reported as a limit (the forecaster's own chance of this, stated with the estimate: 85%); the middle value does not contradict the limit.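

No new step can be read between compound 1 and compound 4, because both results are limits and neither gives a single number: the limit of > 100000 nM in this assay, at which 3 of the 4 values shown sit. The compounds shown leave open how acetyl and 2-(2-hydroxyethoxy)ethyl on an aromatic nitrogen compare, and whether any change on the shared core gives a single figure in this assay.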